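A few compounds are considered here, and "the series" means these few. Any claim that something is new, unique, unknown or untested is made for them only; others in the source may bear on it.

In an ADME assay on BJ cells (Homo sapiens) for cytotoxicity, with a stated time of 72 h (a lower number here means that less compound is needed, a higher number that more compound is needed for the effect), compound 1 `Cc1ccc(-c2nc3c(c(C)nn3-c3ccccc3)c(-c3ccccc3O)c2C#N)cc1` gives 22200 nM and compound 2 `Cc1ccccc1-c1nc2c(c(C)nn2-c2ccccc2)c(-c2ccccc2O)c1C#N` gives 21000 nM, which places compound 2 level with compound 1 within the scatter. Compound 3 `Cc1nn(-c2ccccc2)c2nc(-c3ccc(C(C)C)cc3)c(C#N)c(-c3ccccc3O)c12` has 4-isopropylphenyl in place of 2-methylphenyl on an aromatic carbon, ortho to a cyano group (4-isopropylphenyl in place of 2-methylphenyl on an aromatic carbon). Among the compounds with values here, the one measured step that bears on this is a 1.1-fold lower number from compound 1 to compound 2 (0.02 log units; within the scatter), where 2-methylphenyl replaces 4-methylphenyl at the same place. Within the data shown here, no measured compound carries 4-isopropylphenyl, so that evidence is limited, and no change beyond the scatter is expected in this assay. The expected step is a 1.1-fold lower number from compound 2 to compound 3 (0.02 log units; within the scatter). Compound 3 is estimated at 20000 nM, with an expected range of 9000 nM to 42000 nM.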

Compound 3, half-maximal effective concentration: 22600 nM
For compound 3 the middle estimate is 1.1-fold (0.05 log units) below the measured one; the range from low to high includes it.
By their numbers in this assay, from the lowest: compounds 2, 1 and 3 (each within the scatter of the next).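

In this assay there is a 1.1-fold higher number from compound 2 to compound 3 (0.03 log units; within the scatter), so 4-isopropylphenyl is tolerated at this position, ortho to a cyano group, as 2-methylphenyl is. There is also a 1.0-fold higher number from compound 1 to compound 3 (0.01 log units; within the scatter), which extends the flat picture to isopropyl in place of methyl on this phenyl ring. Nothing available offers an explanation for this flat result. All three compounds carry only an alkyl group on this phenyl ring. Going by these compounds, whether an amine or a carboxylic acid there would shift the number beyond the scatter remains open.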